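Amide-side substituents in a B1 antagonist series

The compounds below may be only part of what the source reports. "The series", "measured", "known", "first", "only" and "open" are said of these compounds alone.

Measured so far, in an in vitro functional assay on cells for antagonist activity at B1 bradykinin receptor (Homo sapiens), read by luminescence and calcium flux, with a stated time of 2 h; on this read-out lower numbers stand for stronger inhibition and higher numbers for weaker inhibition:
compound 1, `Cc1ccc(S(=O)(=O)N2C=CNC(=O)[C@H]2CC(=O)NC2CCNc3ccccc32)cc1`: 21.6 nM
compound 2, `Cc1ccc(S(=O)(=O)N2C=CNC(=O)[C@H]2CC(=O)NC2CCC(C)CC2)cc1`: 314 nM
compound 3, `Cc1ccc(S(=O)(=O)N2C=CNC(=O)[C@H]2CC(=O)N[C@H]2CCN(C)CC2(C)C)cc1`: 0.42 nM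

Compound 3 stands lowest of the three numbers in this assay: a 51-fold lower number from compound 1 to compound 3 (1.71 log units; beyond the scatter), and a 750-fold lower number from compound 2 to compound 3 (2.87 log units; beyond the scatter), both beyond the scatter. Compound 4, `Cc1ccc(S(=O)(=O)N2C=CNC(=O)[C@H]2CC(=O)N[C@H]2CCN(CC(C)C)CC2(C)C)cc1`, differs from compound 3 by isopropyl in place of hydrogen on a saturated chain carbon bound to an amine nitrogen in a ring.

Among the compounds with values here, none of the measured steps touches this place. Each of them, including a 15-fold higher number from compound 1 to compound 2 (1.16 log units; beyond the scatter), exchanges the whole group on the amide-type nitrogen, so the three large steps bear on the ring system and not on the substituent on the amine nitrogen within it. No direct guide exists in the data. The expected step is therefore a 1.4-fold higher number from compound 3 to compound 4 (0.15 log units; within the scatter), nothing beyond the scatter, with a wide range to cover the uncertainty. Compound 4 is estimated at 0.6 nM, between 0.12 nM and 3 nM.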

Compound 4, half-maximal inhibitory concentration: 0.86 nM
Compound 4: middle estimate off by 1.4-fold (0.16 log units), on the low side; the range from low to high includes it.
By their numbers in this assay, from the lowest: compound 3; then compound 4; then compound 1; then compound 2.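

Methyl to isobutyl, with isopropyl in place of hydrogen on a saturated chain carbon bound to an amine nitrogen in a ring, gives a 2.0-fold higher number from compound 3 to compound 4 (0.31 log units; beyond the scatter) in this assay as the first step at this place. The added carbon costs little here, far less than the steps that exchange the whole group on the amide-type nitrogen. Nothing measured accounts for this step.

The compounds shown leave open how a longer chain, a benzyl group or a carboxylic acid would read at this place. They also leave open whether a hydrogen on the ring amine nitrogen would hold the number.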